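A Methyl Gives Way to Bromo in Compound 3

The compounds below may be only part of what the source reports. "The series", "measured", "known", "first", "only" and "open" are said of these compounds alone.

Of the compounds shown here, two have a measured value so far in an in vivo ADME assay on the whole organism (Rattus norvegicus) for pharmacokinetics, at a dose of 2 mg/kg by the intravenous route (on this read-out lower numbers stand for a shorter-lived compound and higher numbers for a longer-lived compound), and they sit well apart. Compound 1 (`Clc1cncc(OC2C=C(C#Cc3ccccn3)CCC2)c1`) gives 4.8 h there, and compound 2 (`Cc1ccc(S(=O)(=O)N2CC=C(C#Cc3ccccn3)CC2)cc1`) gives 1.5 h as the lower of the two numbers, a gap beyond the usual scatter. The two differ in more than one place, so their gap says little about any single change. Compound 3 (`O=S(=O)(c1ccc(Br)cc1)N1CC=C(C#Cc2ccccn2)CC1`) has not yet been measured in this assay and departs from compound 2 at one spot, with bromo in place of methyl on an aromatic carbon, para to a large group (bromo in place of methyl on an aromatic carbon). The 4-methylphenyl thus becomes 4-bromophenyl while the rest of the structure stays the same. Among the compounds with values here, no measured pair here shows this swap, so the data point to no direction. Only a small change is expected in this assay, and a 1.1-fold higher number from compound 2 to compound 3 (0.05 log units; within the scatter) is estimated to stay within the scatter. Compound 3 is estimated at 1.7 h with an expected range from 0.8 h to 3.5 h on repeated measurement.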

Compound 3, half-life: 1.1 h
Compound 3: middle estimate off by 1.5-fold (0.19 log units), on the high side; the measured number falls inside the stated range.
By their numbers in this assay, from the lowest: compounds 3 and 2 (each within the scatter of the next); then compound 1.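

In this assay, within the data shown here, compound 2 and compound 3 form the only pair so far that differs in one place, and the change from methyl to bromo gives a 1.4-fold lower number from compound 2 to compound 3 (0.13 log units; within the scatter). At this aromatic carbon, para to a large group, the 4-methylphenyl and the 4-bromophenyl therefore cannot be told apart on half-life, and the swap of these two groups leaves the reading where the scatter alone could put it. Nothing among the data gives a reason for this outcome, so the result stands as an observation only.

What the compounds shown leave open is whether any other group at this same spot, such as a methoxy, an amine or a carboxylic acid, would shift the half-life by more than the scatter, since only methyl and bromo have been compared there. They also leave open how the sulfonyl link or the pyridine-bearing alkyne contributes, as no pair shown differs in one place at either of those parts of the structure.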